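Aryl replacement at the bromo position: compounds 1 to 4

The compounds below may be only part of what the source reports. "The series", "measured", "known", "first", "only" and "open" are said of these compounds alone.

Measured so far:
compound 1 `Brc1cn2ccnc2c(-c2ccc3ncn(C4CCCCC4)c3c2)n1`: 14.9%
compound 2 `COc1ccc(-c2cn3ccnc3c(-c3ccc4ncn(C5CCCCC5)c4c3)n2)cc1`: 95.6%
compound 3 `c1ccc2c(-c3cn4ccnc4c(-c4ccc5ncn(C6CCCCC6)c5c4)n3)cccc2c1`: 22.9%

Three analogues share one core and differ at a single aromatic carbon. In a functional assay on RPMI-8226 cells (Homo sapiens) for inhibition, read by sulforhodamine B assay, with a stated time of 48 h, tested at 10 uM (on this read-out lower numbers stand for less inhibition and higher numbers for more inhibition at the one concentration tested (going by the name of the read-out)), compound 2 gives 95.6%, the high end of the set. Compound 3 stands second of the three numbers, but its nearest neighbour is compound 1 at 14.9%, and a number 8 percentage points higher from compound 1 to compound 3 (within the scatter), so the two are not separable. The only large move in the set is a number 72.7 percentage points lower from compound 2 to compound 3 (beyond the scatter), mirrored by a number 80.7 percentage points higher from compound 1 to compound 2 (beyond the scatter).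

The next compound, compound 4 `Fc1ccc(-c2cn3ccnc3c(-c3ccc4ncn(C5CCCCC5)c4c3)n2)cc1`, is reached from compound 3 by 4-fluorophenyl in place of naphthalen-1-yl on an aromatic carbon. Within the data shown here, the step that bears on this is the one from compound 2 to compound 3, which ran downward and far beyond the scatter when a 4-methoxyphenyl gave way to naphthalen-1-yl. Among the measured compounds shown here, compound 4 returns to a single six-membered ring with a para substituent, as in compound 2, though with fluorine in place of methoxy, and no step from methoxy to fluoro is measured here. An upward step in this assay is therefore expected, a number 42.1 percentage points higher from compound 3 to compound 4 (beyond the scatter), though with wide uncertainty.

Compound 4 is estimated at 65%, in a range from 25% to 95%.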

Compound 4, a percentage reported as inhibition, at one concentration (the size of the read-out at that concentration, not a potency): 50.1%
The estimate for compound 4 lay 14.9 percentage points above the measured number, within the range that was stated.
By their numbers in this assay, from the lowest: compounds 1 and 3 (each within the scatter of the next); then compound 4; then compound 2.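

In this assay the substituent on the aryl ring matters at this position, not just the presence of a single six-membered aryl ring: fluoro in place of methoxy gives a number 45.5 percentage points lower from compound 2 to compound 4 (beyond the scatter) and leaves compound 4 well short of compound 2. The 4-fluorophenyl group still separates from both lower compounds, with a number 35.2 percentage points higher from compound 1 to compound 4 (beyond the scatter) against the bromo group and a number 27.2 percentage points higher from compound 3 to compound 4 (beyond the scatter) against the naphthalen-1-yl group. Among these compounds, this gives the series an intermediate level, where the earlier compounds showed only compound 2 well above a pair, compound 1 and compound 3, that could not be told apart. Nothing available here explains why these groups differ in this way.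

Only two substituted phenyl groups are shown, 4-methoxyphenyl and 4-fluorophenyl, so two points cannot define a trend on that ring, and it remains open where an amine or a carboxylic acid at the same ring carbon, or an ethoxy group as a longer chain in place of methoxy, would fall. Each number also comes from one concentration, which leaves the potency of these compounds open.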